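This account rests on a few compounds, and the source may have more. Where it says the series, first, only, none or still open, it means among the compounds named here.

Compound 1 `Nc1ncnn2c([C@@H]3O[C@H](CO)[C@@H](O)[C@H]3O)cc(-c3ccc(F)cc3F)c12`: 59100 nM
Compound 2 `COc1ccc(-c2cc([C@@H]3O[C@H](CO)[C@@H](O)[C@H]3O)n3ncnc(N)c23)cc1`: 62600 nM
Compound 3 `Nc1ncnn2c([C@@H]3O[C@H](CO)[C@@H](O)[C@H]3O)cc(-c3ccoc3)c12`: 300 nM

In a functional assay on Z-138 cells (Homo sapiens) for antiproliferative activity, with a stated time of 72 h (a higher number here means a weaker inhibitor, a lower number a stronger inhibitor), compound 3 gives 300 nM, the lowest number of the three, and its steps to both others lie beyond the scatter. Compound 4 `Nc1ncnn2c([C@@H]3O[C@H](CO)[C@@H](O)[C@H]3O)cc(-c3ccsc3)c12` is not yet measured. It differs from compound 3 in one place: thiophen-3-yl in place of furan-3-yl on an aromatic carbon. Among the compounds with values here, three measured steps concern this same position. Exchanging the 2,4-difluorophenyl group for the 4-methoxyphenyl group gave a 1.1-fold higher number from compound 1 to compound 2 (0.02 log units; within the scatter). Moving to furan-3-yl gave two large steps, a 200-fold lower number from compound 1 to compound 3 (2.29 log units; beyond the scatter) and a 210-fold lower number from compound 2 to compound 3 (2.32 log units; beyond the scatter). Thus the position can matter greatly, but no measured step exchanges one five-membered aromatic ring for another. Thiophen-3-yl, like furan-3-yl, is one five-membered aromatic ring with 1 hetero atom, so compound 4 is expected to stay close to compound 3, with no step beyond the scatter, though this remains uncertain. The expected change is no change at the digits printed from compound 3 to compound 4 (within the scatter). For compound 4, the estimate is 300 nM, with an expected range of 80 nM to 1200 nM.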

Compound 4, half-maximal inhibitory concentration: 43500 nM
Compound 4: the middle estimate sits 150-fold (2.16 log units) below what was measured; measured number outside the range, above it.
By their numbers in this assay, from the lowest: compound 3; then compounds 4, 1 and 2 (each within the scatter of the next).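

In this assay, the step of a 150-fold higher number from compound 3 to compound 4 (2.16 log units; beyond the scatter) shows that two groups with the same counts, each with 5 heavy atoms in one five-membered aromatic ring with 1 hetero atom, can still behave very differently at this position; the counted difference is sulfur in place of oxygen. The steps of a 1.4-fold lower number from compound 2 to compound 4 (0.16 log units; within the scatter) and a 1.4-fold lower number from compound 1 to compound 4 (0.13 log units; within the scatter) place compound 4 with the two compounds carrying substituted phenyl groups, so having a five-membered ring here does not by itself give the low number of compound 3. Nothing measured here bears on the reason for this gap.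

As far as these compounds go, it remains open whether furan-3-yl is unique or whether other rings, such as furan-2-yl or pyrrol-3-yl, also give low numbers. Smaller groups at this position, such as an amine or a methyl group, also remain open.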